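Aryl ether chain shortening in a thiazolidinedione series

The source may report more compounds than this note shows. Statements on the series, on what has been measured and on what is new or still open speak of the compounds shown alone.

Measured so far in a functional assay on MCF7 cells (Homo sapiens), tested at 5 uM; a lower number here means a stronger effect, a higher number a weaker effect of the compound at the concentration tested:
compound 1 `C=CCOc1c(C)c(C)c2c(c1C)CCC(C)(COc1ccc(/C=C3\SC(=O)NC3=O)cc1)O2`: 42%
compound 2 `C=CCOc1c(C)c(C)c2c(c1C)CCC(C)(COc1ccc(/C=C3\SC(=O)NC3=O)cc1OC)O2`: 5%
compound 3 `CC(C)=CCOc1c(C)c(C)c2c(c1C)CCC(C)(COc1ccc(/C=C3\SC(=O)NC3=O)cc1C)O2`: 56%

Compound 3 stands highest of the three numbers in this assay; the nearest is compound 1, the furthest compound 2, both gaps beyond the scatter. Among the compounds with values here, the only step measured in one place, a number 37 percentage points lower from compound 1 to compound 2 (beyond the scatter), touches a different part of the shared core and does not bear on compound 4 `C=CCOc1c(C)c(C)c2c(c1C)CCC(C)(COc1ccc(/C=C3\SC(=O)NC3=O)cc1C)O2`. Within the data shown here, its change from compound 3, (vinyl in place of 2-methylprop-1-en-1-yl on a saturated chain carbon bound to an oxygen on an aromatic ring), has no measured counterpart; compound 1 and compound 3 differ in two places, so their values show only a combined effect. No step beyond the scatter is therefore expected. Compound 4 is estimated at 52%, range 32% to 72%, an expected step of a number 4 percentage points lower from compound 3 to compound 4 (within the scatter).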

Compound 4, a percentage reported as activity, at one concentration (the size of the read-out at that concentration, not a potency): 24%
Compound 4: middle estimate off by 28 percentage points, on the high side, and the stated range ends above it.
By their numbers in this assay, from the lowest: compound 2; then compound 4; then compound 1; then compound 3.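

In this assay, the change from (3-methylbut-2-en-1-yl)oxy to allyloxy gives a number 32 percentage points lower from compound 3 to compound 4 (beyond the scatter), so this chain end has a large effect on the read-out with the aromatic methyl held constant. With allyloxy fixed, the aromatic carbon now reads as a graded series, hydrogen, methyl, methoxy, through a number 18 percentage points lower from compound 1 to compound 4 (beyond the scatter) and a number 19 percentage points higher from compound 2 to compound 4 (beyond the scatter). No measurement at hand bears on the cause of either change.

Going by these compounds, it remains open whether the allyloxy gain carries over to the methoxy or hydrogen compounds. Also open, on these data alone, is how a benzyl ether or a free hydroxyl would read at this position.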